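A few compounds are considered here, and "the series" means these few. Any claim that something is new, unique, unknown or untested is made for them only; others in the source may bear on it.

Compound 1 `Nc1nc(F)nc2c1ncn2[C@@H]1O[C@H](CO)C=C1F`: > 100000 nM
Compound 2 `Nc1nc(F)nc2c1ncn2[C@H]1O[C@H](CO)C=C1F`: 28300 nM
Compound 3 `Nc1nc(O)c2ncn([C@@H]3O[C@H](CO)C=C3F)c2n1`: > 100000 nM; > 100000 nM (2 entries)

In an ADME assay on CCRF-CEM cells (Homo sapiens) for cytotoxicity (a lower number here means a stronger inhibitor, a higher number a weaker inhibitor), compound 1 gives > 100000 nM, which is a limit and not a number. Compound 4 `Nc1nc(N)c2ncn([C@@H]3O[C@H](CO)C=C3F)c2n1` differs from compound 1 by one swap, amino in place of fluoro on an aromatic carbon, between two ring nitrogen atoms. Within the data shown here, the only measured step, an at least 3.5-fold lower number from compound 1 to compound 2 (0.54 log units; beyond the scatter), does not cover this swap, since it comes with the fact that compounds 1 and 2 differ only in the configuration as drawn. With the configuration of compound 1, compound 3 gives > 100000 nM; > 100000 nM (2 entries), again only a limit. Weak inhibition therefore seems the likeliest outcome, and no clear step is expected in this assay. The estimated change is a number no higher from compound 1 to compound 4 (the limit leaves the size open). For compound 4 the expected value is 100000 nM, with an estimated range of 30000 nM to 200000 nM.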

Compound 4, half-maximal inhibitory concentration: > 100000 nM
Compound 4 was reported as a limit (the forecaster's own chance of this, stated with the estimate: 70%); the middle value sits exactly at the limit.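

Compound 1 and compound 4 are both reported only as a limit, so the step between them cannot be read: the limit of > 100000 nM in this assay, at which 2 of the 4 values shown sit. The compounds shown leave open whether amino in place of fluoro on an aromatic carbon changes the result in this assay at all.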